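A few compounds are considered here, and "the series" means these few. Any claim that something is new, unique, unknown or untested is made for them only; others in the source may bear on it.

Compound 1 `O=c1c(CSC(=S)N2CCCC2)coc2ccccc12` is the parent of this small set. In a functional assay on MCF7 cells (Homo sapiens) for antiproliferative activity, read by MTT assay, with a stated time of 72 h (on this read-out higher numbers stand for weaker inhibition and lower numbers for stronger inhibition), compound 1 gives > 25000 nM, which is a limit of the assay rather than a measured number. Two measured relatives change the aromatic part of the shared core. Compound 2 `COc1ccc2occ(CSC(=S)N3CCCC3)c(=O)c2c1` carries a methoxy in place of hydrogen on an aromatic carbon and gives 34100 nM. The step that the limit leaves unreadable from compound 1 to compound 2 cannot be sized, because compound 1 sits at the limit of > 25000 nM in this assay, at which 1 of the 3 values shown sits. Compound 3 `O=c1c(CSC(=S)N2CCCC2)coc2cc(Cl)ccc12` carries chloro in place of hydrogen on an aromatic carbon and gives 600 nM, which corresponds to the step of an at least 41-fold lower number from compound 1 to compound 3 (1.61 log units; beyond the scatter).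

Compound 4 `CC(C)N(C(=S)SCc1coc2ccccc2c1=O)C(C)C` changes a different place altogether: diisopropylamino in place of pyrrolidin-1-yl on a thiocarbonyl carbon. Neither measured step touches the thiocarbonyl carbon, so both speak to the aromatic part of the core and give no direct guide to this change. Among the measured compounds shown here, with compound 1 at a limit and no comparable step available, the expectation is that compound 4 also remains a weak inhibitor, with an estimated value of 30000 nM and a plausible range from 6000 nM to 150000 nM. The step expected from this estimate is a step that the limit leaves unreadable from compound 1 to compound 4, with a real chance that only a limit is reported.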

Compound 4, half-maximal inhibitory concentration: > 30000 nM
Compound 4 gave a limit, no number; the forecaster's own chance of this, stated with the estimate: 55%; the middle value sits exactly at the limit.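

Compound 1 and compound 4 both end at a limit rather than a measured number, so the change from pyrrolidin-1-yl to diisopropylamino gives no readable step. The compounds shown leave open whether this change on the thiocarbonyl carbon shifts activity at all in this assay.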